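The source may hold more compounds than are shown below. What is called first, only, known or untested is meant among the compounds shown, and "the series" means these compounds.

Measured so far:

compound 1 `O=[N+]([O-])c1cn2c(n1)OCC(COc1ccc(OC(F)(F)F)cc1)C2` — in an ADME assay on Vero cells (Chlorocebus sabaeus) for cytotoxicity, with a stated time of 72 h (on this read-out higher numbers stand for weaker inhibition and lower numbers for stronger inhibition), compound 1 gives > 128000 nM, a limit of the assay rather than a number.

compound 2 `O=[N+]([O-])c1cn2c(n1)OCC(COCc1ccc(OCc3ccccc3)cc1)C2` — in this assay compound 2 gives 113000 nM.

compound 3 `O=[N+]([O-])c1cn2c(n1)OCC(COc1ccc(-c3ccc(OC(F)(F)F)cc3)cn1)C2` — in this assay compound 3 gives > 128000 nM, again a limit and not a number.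

Compound 2 therefore stands as the only number shown in this assay; its value sits just beneath (the limit of > 128000 nM in this assay, at which 2 of the 3 values shown sit). Among the compounds with values here, with only one number and two limits, no step between measured compounds can be drawn, and nothing shows how changes at the outer aromatic ring move the read-out.

Compound 4 `O=[N+]([O-])c1cn2c(n1)OCC(COCc1ccc(-c3ccc(F)cc3)cc1)C2` differs from compound 2 by 4-fluorophenyl in place of benzyloxy on an aromatic carbon. In this assay the step from compound 2 to compound 4 is expected to be none beyond the scatter, since all three measured compounds sit at or near the limit. Compound 4 is expected at 115000 nM, with a range from 55000 nM to 128000 nM. The estimated step is a 1.0-fold higher number from compound 2 to compound 4 (0.01 log units; within the scatter), and a limit rather than a number is a likely outcome.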

Compound 4, half-maximal inhibitory concentration: 24000 nM
Beside the measured number, compound 4's estimate is 4.8-fold (0.68 log units) above it; the whole stated range lies above it.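

In this assay, the group on this aromatic carbon does move the read-out: 4-fluorophenyl in place of benzyloxy gives a 4.7-fold lower number from compound 2 to compound 4 (0.67 log units; beyond the scatter). The earlier compounds shown here, with one number and two limits, offered no step, so they could not show that a change at this place reaches beyond the scatter. With this change, compound 4 becomes the first compound shown to stand clearly away from the limit: the limit of > 128000 nM in this assay, at which 2 of the 4 values shown sit.

This single change leaves open whether the step goes with the loss of the oxygen of benzyloxy or with the fluorine of 4-fluorophenyl, and a plain phenyl group at the same place would help to separate the two. Going by these compounds, how an amine or a carboxylic acid on the outer ring would read here also stays open.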